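The source may hold more compounds than are shown below. What is called first, only, known or untested is meant among the compounds shown, and "the series" means these compounds.

Of the compounds shown here, two of a shared core have been tested in an ADME assay on Jurkat cells (Homo sapiens) for cytotoxicity, read by MTT assay, with a stated time of 72 h; a higher number here means that more compound is tolerated, a lower number that less compound is tolerated. Compound 1 `COc1ccc(C2=Cc3ccc([N+](=O)[O-])cc3C(CC(C)=O)N2c2ccc(C)cc2)cc1` gives 33100 nM in this assay, and compound 2 `COc1ccc(C2=Cc3ccc(F)cc3C(CC(=O)CO)N2c2ccc([N+](=O)[O-])cc2)cc1` gives 57100 nM. These two values lie within the scatter of repeated measurements, so the data so far show no separation between compound 1 and compound 2 in this assay.

Compound 3 `COc1ccc(C2=Cc3ccc(F)cc3C(CC(=O)C(C)O)N2c2ccc([N+](=O)[O-])cc2)cc1` has not yet been measured in this assay. It differs from compound 2 in one place: methyl in place of hydrogen on a saturated chain carbon bound to a carbonyl carbon and an oxygen on a saturated carbon. For the measured compounds named here, no measured pair shows what such a change does in this assay, so the expectation for compound 3 rests on the structural change being small and on compound 2 sitting where it does. For compound 3 the expected outcome is a step from compound 2 that stays within the scatter, a 1.1-fold lower number from compound 2 to compound 3 (0.06 log units; within the scatter). The estimate for compound 3 in this assay is therefore 50000 nM, with a range from 20000 nM to 120000 nM.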

Compound 3, half-maximal cytotoxic concentration: 6100 nM
Beside the measured number, compound 3's estimate is 8.2-fold (0.91 log units) above it; the whole stated range lies above it.
By their numbers in this assay, from the lowest: compound 3; then compounds 1 and 2 (each within the scatter of the next).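

In this assay, the change from hydroxymethyl to 1-hydroxyethyl gives a 9.4-fold lower number from compound 2 to compound 3 (0.97 log units; beyond the scatter), so a single added methyl on this saturated chain carbon bound to a carbonyl carbon and an oxygen on a saturated carbon moves the number beyond the scatter. The earlier compounds shown here differ from each other in more than one place and gave no reading of this position, whereas this step isolates one small change that lowers the tolerated concentration. Nothing available accounts for the size of this step.

The compounds shown leave open whether a longer chain, such as ethyl in place of the added methyl, would lower the number further, and whether an amine in place of the hydroxyl on that carbon would give a similar step. They also leave open whether the same methyl would give a step of like size with the other substituents of compound 1.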